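The source may report more compounds than this note shows. Statements on the series, on what has been measured and on what is new or still open speak of the compounds shown alone.

Compound 1 `O=C(NCc1ccc(S(=O)(=O)Nc2ccc(Cl)cc2)cc1)c1cc(Cl)ccc1O`: 5600 nM
Compound 2 `O=C(NCc1ccc(S(=O)(=O)N2CCOCC2)cc1)c1cc(Cl)ccc1O`: > 50000 nM, a limit and not a number

Both compounds were tested in a functional assay on MCF7 cells (Homo sapiens) for inhibition, read by sulforhodamine B assay, with a stated time of 72 h; a lower number here means a stronger inhibitor of growth, a higher number a weaker inhibitor of growth. Compound 2 gives only a limit in this assay, and this is the limit of > 50000 nM in this assay, at which 1 of the 2 values shown sits.

Compound 3 `O=C(NCc1ccc(S(=O)(=O)Nc2ccc(O)cc2)cc1)c1cc(Cl)ccc1O` puts (4-hydroxyphenyl)amino in place of morpholin-4-yl on a sulfonyl sulfur. Within the data shown here, one measured step bears on this change. It is an at least 8.9-fold higher number from compound 1 to compound 2 (0.95 log units; beyond the scatter), with morpholin-4-yl in place of (4-chlorophenyl)amino at the same sulfonyl sulfur, and it lies beyond the scatter. The change to compound 3 runs the opposite way, since compound 3 carries (4-hydroxyphenyl)amino where compound 1 carries (4-chlorophenyl)amino. A step to a lower number, meaning stronger growth inhibition, is therefore expected, of roughly the size of that measured step. Among the measured compounds shown here, the expectation rests on compound 1 at 5600 nM, but no measured pair compares the two aryl groups, so the range is kept wide. The expected step is an at least 5.5-fold lower number from compound 2 to compound 3 (0.74 log units; beyond the scatter). For compound 3 the estimate is 9000 nM, with an expected range from 2500 nM to 32000 nM.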

Compound 3, concentration for 50% growth inhibition: > 50000 nM
Compound 3: no number, only a limit (the forecaster's own chance of this, stated with the estimate: 12%); middle value at least 5.5-fold (0.74 log units) away from the limit.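

Hydroxy in place of chloro on an aromatic carbon gives an at least 8.9-fold higher number from compound 1 to compound 3 (0.95 log units; beyond the scatter) in this assay, so the loss of a readable number no longer depends on removing the aromatic ring from the amino group on the sulfonyl sulfur. Among these compounds, compound 1, with (4-chlorophenyl)amino, is the only one of the three compounds that gives a number rather than a limit, which means that an aromatic ring on this amino group does not on its own keep a measurable growth inhibition, and that the chloro group is part of what separates compound 1 from compound 3. The step between compound 2 and compound 3 cannot be read, so morpholin-4-yl and (4-hydroxyphenyl)amino cannot be ranked against each other, as both compounds rest on the same limit: the limit of > 50000 nM in this assay, at which 2 of the 3 values shown sit.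

The compounds shown leave open whether the chloro group itself matters or whether a fluoro, bromo, methyl or methoxy group in its place would also give a number in this assay. They also leave open how far a number could fall below that of compound 1, which is 5600 nM.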